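This account rests on a few compounds, and the source may have more. Where it says the series, first, only, none or still open, it means among the compounds named here.

Measured compounds, in a functional assay on K562 cells (Homo sapiens) for inhibition, read by fluorescence, with a stated time of 72 h; a lower number here means a stronger inhibitor of growth, a higher number a weaker inhibitor of growth:
compound 1 `CC(C)c1nccc2nn(-c3ccccc3)cc12`, > 100000 nM, a limit of the assay.
compound 2 `CC(C)c1nc(-c2ccccc2)cc2nn(-c3ccccc3)cc12`, 36800 nM.
compound 3 `c1ccc(-n2cc3cnccc3n2)cc1`, > 100000 nM, a limit of the assay.

Compound 4 `c1ccc(-c2cc3nn(-c4ccccc4)cc3cn2)cc1` is not yet measured. Its core differs from that of compound 1 by hydrogen in place of isopropyl on an aromatic carbon; the step there is a step that the two limits leave unreadable from compound 1 to compound 3 because of the limit of > 100000 nM in this assay, at which 2 of the 3 values shown sit.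

The change from compound 3 to compound 4 is phenyl in place of hydrogen on an aromatic carbon. The same kind of change, (phenyl in place of hydrogen on an aromatic carbon), made the step of an at least 2.7-fold lower number from compound 1 to compound 2 (0.43 log units; beyond the scatter), in this assay; the place differs in that the earlier change sits meta to an isopropyl group and the new one does not.

For compound 4 the expected step is an at least 1.6-fold lower number from compound 3 to compound 4 (0.22 log units; that floor lies within the scatter), resting on an at least 2.7-fold lower number from compound 1 to compound 2 (0.43 log units; beyond the scatter) and on the fact that compound 3 gives only a limit. The estimate for compound 4 is 60000 nM, between 20000 nM and 200000 nM.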

Compound 4, concentration for 50% growth inhibition: 3400 nM
Compound 4: middle estimate off by 18-fold (1.25 log units), on the high side; measured number outside the range, below it.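

In this assay, phenyl in place of hydrogen on an aromatic carbon lowers the number on both cores, and on the core of compound 3 the step is an at least 29-fold lower number from compound 3 to compound 4 (1.46 log units; beyond the scatter). The change carries over in direction, but no difference in size between the two cores can be claimed: the same change on two cores in this assay, an at least 2.7-fold lower number (0.43 log units; beyond the scatter) from compound 1 to compound 2 and an at least 29-fold lower number (1.46 log units; beyond the scatter) from compound 3 to compound 4; the limit leaves it open whether they differ. With phenyl present, hydrogen in place of isopropyl gives an 11-fold lower number from compound 2 to compound 4 (1.03 log units; beyond the scatter), whereas the same change without phenyl cannot be read: the limit of > 100000 nM in this assay, at which 2 of the 4 values shown sit.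

The compounds shown leave open whether phenyl itself matters, as an amine, a carboxylic acid or a longer alkyl chain at the same place has no value here. Also open, on these data alone, is whether either step would hold on a further core.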